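Chloro for methoxy on the benzyl group: working notes

The compounds below may be only part of what the source reports. "The series", "measured", "known", "first", "only" and "open" are said of these compounds alone.

Measured so far:
compound 1 `COc1ccc(CN(C(=O)CSc2nc3ccccc3s2)c2cc(OC)c(OC)c(OC)c2)cc1` — 163 nM
compound 2 `COc1ccc2nc(SCC(=O)N(Cc3ccc(OC)c(O)c3)c3cc(OC)c(OC)c(OC)c3)sc2c1` — 71 nM

Within the data shown here, in a functional assay on MGC-803 cells (Homo sapiens) for antiproliferative activity, read by MTT assay, with a stated time of 48 h (a lower number here means a stronger inhibitor, a higher number a weaker inhibitor), compound 1 gives 163 nM, the highest of the two numbers so far; compound 2 gives 71 nM, a gap that lies beyond the scatter. Compound 3 `COc1cc(N(Cc2ccc(Cl)cc2)C(=O)CSc2nc3ccccc3s2)cc(OC)c1OC` differs from compound 1 by chloro in place of methoxy on an aromatic carbon. Among the measured compounds shown here, no measured pair shows this change, so nothing sets its size; a small step in either direction, likely within the scatter, is the expectation. Compound 3 is expected to give 150 nM, with a range of 55 nM to 420 nM. That expectation corresponds to an estimated step of a 1.1-fold lower number from compound 1 to compound 3 (0.04 log units; within the scatter).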

Compound 3, half-maximal inhibitory concentration: > 80000 nM
Compound 3 gave a limit, no number; the forecaster's own chance of this, stated with the estimate: 3%; at least 530-fold (2.72 log units) between middle value and limit.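

In this assay, going from 4-methoxybenzyl to 4-chlorobenzyl gives an at least 490-fold higher number from compound 1 to compound 3 (2.69 log units; beyond the scatter), so a single exchange at this position can decide the activity of the series. The reading for compound 3 is a limit of the assay, not a number: the limit of > 80000 nM in this assay, at which 1 of the 3 values shown sits. Compound 2 differs from compound 1 in more than one place, and neither compound gave any sign of this sensitivity.

As far as these compounds go, the full size of the step remains unknown. From the compounds shown here alone, it is also open whether a fluoro group or an amine at this position would keep the activity of compound 1.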